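A few compounds are considered here, and "the series" means these few. Any claim that something is new, unique, unknown or untested is made for them only; others in the source may bear on it.

Compound 1 `COc1ccc(/C=C\c2cc(OC)c(OC)c(OC)c2)cc1NC(=O)[C@H](CO)NC(=O)[C@H](CCCNC(=N)N)NC(=O)[C@H](CCCCN)NC(=O)c1ccccc1` - 134 nM 
Compound 2 `COc1ccc(/C=C\c2cc(OC)c(OC)c(OC)c2)cc1NC(=O)[C@H](C)NC(=O)[C@H](CCCNC(=N)N)NC(=O)[C@H](CCCCN)NC(=O)c1ccccc1` - 71.6 nM 

Both numbers come from an ADME assay on Huh-7 cells (Homo sapiens) for cytotoxicity, with a stated time of 72 h (on this read-out higher numbers stand for lower toxicity in this test and lower numbers for higher toxicity in this test), and they are the only two measured so far. Compound 1 stands at 134 nM and compound 2 at 71.6 nM on this scale, and the two cannot be told apart: a 1.9-fold lower number from compound 1 to compound 2 (0.27 log units; within the scatter) is the whole gap between them.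

Compound 3 `COc1ccc(/C=C\c2cc(OC)c(OC)c(OC)c2)cc1NC(=O)[C@H](CO)NC(=O)[C@H](CCCNC(=N)N)NC(=O)[C@H](CCCNC(=N)N)NC(=O)c1ccccc1` keeps the rest of compound 1 and alters one chain, where the aminomethyl leaves and a group with no common name enters: a group of 4 heavy atoms (1 carbon, 3 nitrogen; no ring) in place of a group of 2 heavy atoms (1 carbon, 1 nitrogen; no ring), on a saturated chain carbon, four bonds along the chain from an amide-type nitrogen and a carbonyl carbon is the count of that change.

Going by the values given here, the one measured step bears on this only loosely. It swaps hydroxy for hydrogen two bonds along the chain from an amide-type nitrogen and a carbonyl carbon, not four, and a 1.9-fold lower number from compound 1 to compound 2 (0.27 log units; within the scatter) stayed inside the scatter. No measurement tests the new group directly, so no step beyond the scatter is expected in this assay and no direction can be argued. The estimated change is a 1.1-fold lower number from compound 1 to compound 3 (0.03 log units; within the scatter) and no more than that. For compound 3 the expected value is 125 nM with an estimated range from 45 nM to 350 nM as the likely span.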

Compound 3, half-maximal cytotoxic concentration: 23.1 nM
For compound 3 the middle estimate is 5.4-fold (0.73 log units) above the measured one, and the stated range ends above it.
By their numbers in this assay, from the lowest: compound 3; then compounds 2 and 1 (each within the scatter of the next).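

Going by these compounds alone, this is the first single change to move the number beyond the usual scatter. In this assay, putting the group of 4 heavy atoms (1 carbon, 3 nitrogen; no ring) in place of aminomethyl, on a saturated chain carbon, four bonds along the chain from an amide-type nitrogen and a carbonyl carbon, gives a 5.8-fold lower number from compound 1 to compound 3 (0.76 log units; beyond the scatter), which means higher toxicity in this test, so the group at this place can change the result. Nothing available explains how this swap produces that shift.

One pair cannot separate the parts of the change, since the entering group differs from aminomethyl in its heavy atoms, its double bond and its count of hydrogen-bond donors all at once. From the compounds shown here alone, whether a urea or a longer chain ending in an amine at this place would give a similar number remains open, as does whether the same swap would have a similar effect on compound 2, which carries a methyl group where compound 1 has a hydroxymethyl group.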